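This account rests on a few compounds, and the source may have more. Where it says the series, first, only, none or still open, it means among the compounds named here.

Measured in a functional assay on MGC-803 cells (Homo sapiens) for antiproliferative activity, read by CCK-8 assay, with a stated time of 72 h, tested at 8 uM; on this read-out higher numbers stand for a stronger effect at the one concentration tested and lower numbers for a weaker effect:
- compound 1 `Nc1ccccc1NC(=O)c1ccc(CSC(=S)N2CCN(c3ccccc3)CC2)cc1` gives 87.4%
- compound 2 `Nc1ccccc1NC(=O)c1ccc(CSC(=S)N2CCCc3ccccc32)cc1` gives 87.5%
- compound 3 `CCN(Cc1ccncc1)C(=S)SCc1ccc(C(=O)Nc2ccccc2N)cc1` gives 85.2%

Compound 1 stands second highest of the three numbers; compound 2 sits a hair above it and compound 3 a little below, both gaps within the scatter. Among the measured compounds shown here, the one step recorded so far, a number 2.3 percentage points lower from compound 2 to compound 3 (within the scatter), swaps the group on the thiocarbonyl carbon and is within the scatter. Compound 4 `Nc1ccccc1NC(=O)c1ccc(CSC(=S)N2CCN(c3ccccc3F)CC2)cc1` differs from compound 1 elsewhere: fluoro in place of hydrogen on an aromatic carbon. For the measured compounds named here, no recorded step touches that aromatic ring, so nothing bears directly on the change; the series so far is flat. The expected step in this assay is therefore none beyond the scatter, a number 0.4 percentage points lower from compound 1 to compound 4 (within the scatter). Compound 4 is estimated at 87%, between 78% and 95%.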

Compound 4, a percentage reported as inhibition, at one concentration (the size of the read-out at that concentration, not a potency): 86.4%
Compound 4: the middle estimate sits 0.6 percentage points above what was measured; the measured number falls inside the stated range.
By their numbers in this assay, from the lowest: compounds 3, 4, 1 and 2 (each within the scatter of the next).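

In this assay, among the compounds shown here, the change from phenyl to 2-fluorophenyl gives a number 1 percentage points lower from compound 1 to compound 4 (within the scatter) and is the first step read on this aromatic ring. This carbon, ortho to a large group, therefore accepts fluoro without a change beyond the scatter. Nothing measured speaks to the reason for this result.

Still open, going by these compounds, is whether a larger substituent at this place, such as methoxy, trifluoromethyl or an amine, would hold the number as fluoro does. Chloro on this same carbon is likewise open.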